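The compounds below may be only part of what the source reports. "The series", "measured", "known", "first", "only" and "open" are said of these compounds alone.

Compound 1 `O=C(Nc1ccc(Br)cc1)N1CCC[C@H]1c1nc(-c2ccccc2)no1` and compound 2 `O=C(Nc1ccc(I)cc1)N1CCC[C@H]1c1nc(-c2ccccc2)no1` share one core, and compound 3 `O=C(Nc1ccc(Cl)cc1)N1CCC[C@H]1c1nc(-c2ccc(Br)cc2)no1` carries a different core; the difference between the two cores is not broken down here. Compound 4 `O=C(Nc1ccc(Cl)cc1)N1CCC[C@H]1c1nc(-c2ccc(I)cc2)no1` has not yet been measured. In an ADME assay on MCF-10A cells (Homo sapiens) for inhibition, with a stated time of 48 h (on this read-out lower numbers stand for stronger inhibition and higher numbers for weaker inhibition), compound 1 gives > 50000 nM, which is a limit of the assay and not a number. In this assay compound 2 gives > 50000 nM, again a limit. In this assay compound 3 gives > 50000 nM, also a limit. The change iodo in place of bromo on an aromatic carbon gives a step that the two limits leave unreadable from compound 1 to compound 2, because the limit of > 50000 nM in this assay, at which 3 of the 3 values shown sit, leaves its size unreadable. The same change, (iodo in place of bromo on an aromatic carbon), is made on compound 3. Compound 4 is expected to move by a step that the limit leaves unreadable from compound 3 to compound 4, since compound 3 gives > 50000 nM and the earlier step sits at the limit. Compound 4 is estimated at 80000 nM, between 20000 nM and 300000 nM.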

Compound 4, half-maximal inhibitory concentration: > 50000 nM
Compound 4 ended at the assay's limit (the forecaster's own chance of this, stated with the estimate: 85%); the middle value is on the limit's open side.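

The step from compound 3 to compound 4 in this assay cannot be read, and the cause is this: the limit of > 50000 nM in this assay, at which 4 of the 4 values shown sit.

The compounds shown leave open whether iodo in place of bromo changes inhibition at all, and how the four compounds rank against one another.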